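This account rests on a few compounds, and the source may have more. Where it says the series, first, only, none or still open, it means among the compounds named here.

Series notes. The shared core of compound 1 `COc1ccccc1C(=O)Nc1cccc(NC(=O)c2cccc(F)c2)c1` carries on one amide carbonyl a 3-fluorophenyl group; in an in vitro functional assay on HEK293-A cells for antagonist activity at metabotropic glutamate receptor 5 (Rattus norvegicus), read by calcium flux (a lower number here means a stronger inhibitor, a higher number a weaker inhibitor), compound 1 gives 6480 nM. Compound 2 `COc1ccccc1C(=O)Nc1cccc(NC(=O)c2ccco2)c1` differs from it in that carbonyl substituent only. In this assay compound 2 gives > 30000 nM, which is a limit of the assay and not a number. The measured change is an at least 4.6-fold higher number from compound 1 to compound 2 (0.66 log units; beyond the scatter); because compound 2 sits at the limit of > 30000 nM in this assay, at which 1 of the 2 values shown sits, only the floor of that step is known, and compound 2 therefore stands at the weak end of the two values shown.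

Compound 3 `COCC(=O)Nc1cccc(NC(=O)c2ccccc2OC)c1` is the next compound in the series: methoxymethyl in place of furan-2-yl on a carbonyl carbon. Among the measured compounds shown here, no measured pair shows this exact change; the only step that bears on it is an at least 4.6-fold higher number from compound 1 to compound 2 (0.66 log units; beyond the scatter), in which one aromatic group was exchanged for another and the number rose. The step from compound 2 to compound 3 starts from a limit, so in this assay compound 3 is expected to return no number either, with no move beyond the scatter that the assay could record. The expected step is a step that the limit leaves unreadable from compound 2 to compound 3. For compound 3 the estimate is 40000 nM, within 15000 nM to 120000 nM.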

Compound 3, half-maximal inhibitory concentration: > 30000 nM
Compound 3: a limit, no number (the forecaster's own chance of this, stated with the estimate: 80%); the middle value lies beyond the limit too.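

The change from an aromatic group to an open chain adds a new case: in this assay, methoxymethyl in place of 3-fluorophenyl on the carbonyl carbon gives an at least 4.6-fold higher number from compound 1 to compound 3 (0.66 log units; beyond the scatter). Among the three groups shown on this carbonyl carbon, whose other neighbour is an amide-type nitrogen, only the 3-fluorophenyl of compound 1 returns a number, 6480 nM, while neither the five-membered aromatic ring of furan-2-yl nor the ringless methoxymethyl does. The step between furan-2-yl and methoxymethyl cannot be read, and the step from 3-fluorophenyl to methoxymethyl is known only as a floor, because both compound 2 and compound 3 end at the same bound: the limit of > 30000 nM in this assay, at which 2 of the 3 values shown sit.

The compounds shown do not separate the contribution of the fluorine from that of the six-membered aromatic ring, so it remains open whether an unsubstituted phenyl on this carbonyl carbon would return a number. As far as these compounds go, it is equally open whether a 3-chlorophenyl, a 3-pyridyl or a longer chain ending in an amine would return a number in this assay, and how any such value would compare with that of compound 1.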